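Two Fluorines on the Sulfonyl Phenyl Ring

The source may hold more compounds than are shown below. What is called first, only, known or untested is meant among the compounds shown, and "the series" means these compounds.

Measured in an assay on isolated protein for displacement of a labelled ligand from metabotropic glutamate receptor 5 (Homo sapiens), with a stated time of 60 min, tested at 1 uM; a lower number here means less inhibition, a higher number more inhibition at the concentration tested (going by the name of the read-out):
Compound 1 `CC1CCN(c2c(S(=O)(=O)c3ccccc3)cnc3ccccc23)CC1` gives 89.2%.
Compound 2 `COc1ccc(S(=O)(=O)c2cnc3cc(Cl)ccc3c2N2CCC(C)CC2)cc1Cl` gives 93%.
Compound 3 `CC1CCN(c2c(S(=O)(=O)c3ccccc3)cnc3cc(Cl)ccc23)CC1` gives 93%.

Compound 3 stands level with compound 2 at the digits given, and the two together are the highest of the three numbers; the chloro-for-hydrogen step is a number 3.8 percentage points higher from compound 1 to compound 3 (within the scatter), so all three compounds sit within the scatter of one another in this assay. For the measured compounds named here, the one change already probed at the sulfonyl sulfur, no change at the digits printed from compound 2 to compound 3 (within the scatter), shows that exchanging the ring on that sulfur left the read-out where it was.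

Compound 4 `CC1CCN(c2c(S(=O)(=O)c3cc(F)cc(F)c3)cnc3cc(Cl)ccc23)CC1` differs from compound 3 only there: 3,5-difluorophenyl in place of phenyl on a sulfonyl sulfur. The step from compound 2 to compound 3 is the measurement that bears on this, and it was flat. Compound 4 is therefore expected to give 91% in this assay, with a range from 80% to 98%. That means an estimated step of a number 2 percentage points lower from compound 3 to compound 4 (within the scatter) in this assay, none beyond the scatter.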

Compound 4, a percentage reported as inhibition, at one concentration (the size of the read-out at that concentration, not a potency): 94%
The estimate for compound 4 lay 3 percentage points below the measured number, and the stated range covers the measured number.
By their numbers in this assay, from the lowest: compounds 1, 2, 3 and 4 (each within the scatter of the next).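

In this assay, the 3,5-difluorophenyl group on the sulfonyl sulfur gave a number 1 percentage points higher from compound 3 to compound 4 (within the scatter), so this position now holds three different aryl groups with no step beyond the scatter. The comparison of the two substituted rings, a number 1 percentage points higher from compound 2 to compound 4 (within the scatter), agrees: two fluorines serve here as well as the chloro and methoxy pair, and a single concentration does not separate them. No measurement offered here explains why the read-out stays so flat at this position.

The compounds shown leave open whether a group without an aromatic ring, such as a methyl or a cyclohexyl on the sulfonyl sulfur, would keep the number. They also leave open whether an amine or a carboxylic acid on the phenyl ring would move it beyond the scatter.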